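Hydroxy to hydrogen on the piperidine of compound 2

The source may report more compounds than this note shows. Statements on the series, on what has been measured and on what is new or still open speak of the compounds shown alone.

Measured so far in a functional assay on OVCAR-8 cells (Homo sapiens) for antiproliferative activity; a lower number here means a stronger inhibitor, a higher number a weaker inhibitor:

Compound 1 `Cn1ncc(Cl)c1-c1cc(C(=O)N[C@@H]2CN[C@H](CC(O)CO)C[C@H]2c2ccc(F)c(F)c2)oc1Cl` gives 690 nM
Compound 2 `Cn1ncc(Cl)c1-c1cc(C(=O)N[C@@H]2CN[C@H](CCN3CCC(O)CC3)C[C@H]2c2ccc(Cl)c(Cl)c2)oc1Cl` gives 15900 nM

Compound 2 holds the higher of these two numbers, and its gap to compound 1 lies beyond the scatter, although the two compounds differ in more than one place. Compound 3 `Cn1ncc(Cl)c1-c1cc(C(=O)N[C@@H]2CN[C@H](CCN3CCCCC3)C[C@H]2c2ccc(Cl)c(Cl)c2)oc1Cl` departs from compound 2 by a single change, (hydrogen in place of hydroxy on a saturated ring carbon), with hydrogen in place of hydroxy on a saturated ring carbon, so that 2-(4-hydroxypiperidin-1-yl)ethyl becomes 2-(piperidin-1-yl)ethyl. Among the measured compounds shown here, no measured pair shows this change, so any expectation is tentative. With compound 2 at 15900 nM in this assay, a move to a lower number, beyond the scatter, is expected. The estimated move is a 5.3-fold lower number from compound 2 to compound 3 (0.72 log units; beyond the scatter) in size. For compound 3 the estimated value is 3000 nM, within an expected range from 600 nM to 15000 nM at its ends.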

Compound 3, half-maximal inhibitory concentration: 1660 nM
Estimate against measurement, compound 3: 1.8-fold (0.26 log units) above; measured number inside the range.
By their numbers in this assay, from the lowest: compound 1; then compound 3; then compound 2.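

In this assay, replacing the hydroxy on the saturated ring carbon with hydrogen, so that 2-(4-hydroxypiperidin-1-yl)ethyl becomes 2-(piperidin-1-yl)ethyl, gives a 9.6-fold lower number from compound 2 to compound 3 (0.98 log units; beyond the scatter) and so shows that this position responds to the change. Compound 1 and compound 2 differ in more than one place, so their gap could not be tied to any single group, whereas this pair isolates the hydroxy alone. No measurement shown here accounts for the size or direction of this step.

Going by these compounds, whether the same step would appear with a methoxy, a fluorine or an amine on this ring carbon remains open. On these data alone, it is also open how a morpholine in place of the piperidine, or a longer chain in place of the ethyl, would read in this assay and whether the step holds there.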